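Swapping chloro for bromo on the anilino ring

This account rests on a few compounds, and the source may have more. Where it says the series, first, only, none or still open, it means among the compounds named here.

Three compounds have been measured in a functional assay on U2OS cells (Homo sapiens) for cytotoxicity, read by MTT assay, with a stated time of 48 h; on this read-out higher numbers stand for weaker inhibition and lower numbers for stronger inhibition:
Compound 1 `COc1ccccc1Nc1nc(-c2cccc(F)c2)nc2ccc(F)cc12` gives > 50000 nM, a limit of the assay.
Compound 2 `Fc1cccc(Nc2nc(-c3cccc(F)c3)nc3ccc(F)cc23)c1` gives 49600 nM.
Compound 3 `Fc1cccc(-c2nc(Nc3cccc(Cl)c3)c3cc(F)ccc3n2)c1` gives > 50000 nM, again a limit.

Compound 3 therefore sits at the edge of what the assay can report, and the limit of > 50000 nM in this assay, at which 2 of the 3 values shown sit, shows that this is true of most of the set. The step of a number no lower from compound 2 to compound 3 (the limit leaves the size open) and the step that the two limits leave unreadable from compound 1 to compound 3 are both unreadable in size for that reason. Compound 4 `Fc1cccc(-c2nc(Nc3cccc(Br)c3)c3cc(F)ccc3n2)c1` differs from compound 3 by bromo in place of chloro on an aromatic carbon. Within the data shown here, the only step that bears on it, the halogen swap from compound 2 to compound 3, gave no readable size, so no change beyond the scatter is expected in this assay; the step of a number no higher from compound 3 to compound 4 (the limit leaves the size open) is estimated to be flat, with compound 4 expected at 50000 nM, between 25000 nM and 100000 nM.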

Compound 4, half-maximal inhibitory concentration: > 50000 nM
Compound 4: only a limit was reported (the forecaster's own chance of this, stated with the estimate: 80%); the middle value lies on the limit itself.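

Compound 4 carries 3-bromophenyl where compound 3 carries 3-chlorophenyl. In this assay compound 4 gives > 50000 nM, which is a limit and not a number. Bromo in place of fluoro at this place gives a number no lower from compound 2 to compound 4 (the limit leaves the size open). The steps to compound 4 cannot be read in size, so this swap adds only that bromo at this place also leaves the value at the limit. The set now gathers at one edge of the read-out: the limit of > 50000 nM in this assay, at which 3 of the 4 values shown sit.

Going by these compounds, whether chloro and bromo differ at all here stays open. So does whether a different group at this place, such as an amine or a carboxylic acid, would give a readable value.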